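This account rests on a few compounds, and the source may have more. Where it says the series, first, only, none or still open, it means among the compounds named here.

The series keeps one shared core and varies it at two places. Compound 1 `CC(C)NC(=O)N1CCN(C(=S)SCc2cn(Cc3ccccc3F)nn2)CC1` gives 1620 nM in a functional assay on MGC-803 cells (Homo sapiens) for cytotoxicity, read by MTT assay, with a stated time of 72 h; a higher number here means a weaker inhibitor, a lower number a stronger inhibitor. Compound 2 `O=C(NC1CCCCC1)N1CCN(C(=S)SCc2cn(Cc3ccccc3F)nn2)CC1` gives 36500 nM in this assay, while compound 3 `CC(C)NC(=O)N1CCN(C(=S)SCc2cn(Cc3ccc(F)cc3)nn2)CC1` gives 760 nM in this assay. Compound 3 therefore holds the lowest number of the three: its nearest neighbour is compound 1, separated by the step of a 2.1-fold lower number from compound 1 to compound 3 (0.33 log units; beyond the scatter), and compound 2 lies furthest away from it. The unmeasured compound 4 `O=C(NC1CCCCC1)N1CCN(C(=S)SCc2cn(Cc3ccc(F)cc3)nn2)CC1` differs from compound 3 by cyclohexyl in place of isopropyl on an amide-type nitrogen. Among the compounds with values here, one measured step bears directly on this change, namely a 23-fold higher number from compound 1 to compound 2 (1.35 log units; beyond the scatter), the same exchange carried out on the core that bears the 2-fluorophenyl group. A step of comparable size, towards a higher number, is therefore expected in this assay when moving to compound 4, the estimated step being a 22-fold higher number from compound 3 to compound 4 (1.35 log units; beyond the scatter). On that basis compound 4 is expected to give about 17000 nM in this assay, with a plausible range from 5000 nM to 60000 nM.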

Compound 4, half-maximal inhibitory concentration: > 128000 nM
Compound 4: a limit, no number; the forecaster's own chance of this, stated with the estimate: 5%; middle value at least 7.5-fold (0.87 log units) away from the limit.
By their numbers in this assay, from the lowest: compound 3; then compound 1; then compound 2. At a limit, above all of these: compound 4.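

Cyclohexyl in place of isopropyl on an amide-type nitrogen costs more on the core bearing the 4-fluorophenyl group, with an at least 160-fold higher number from compound 3 to compound 4 (2.22 log units; beyond the scatter), so the size of this change depends on the other place of variation: the same change on two cores in this assay, a 23-fold higher number (1.35 log units; beyond the scatter) from compound 1 to compound 2 and an at least 160-fold higher number (2.22 log units; beyond the scatter) from compound 3 to compound 4, at least 7.4-fold (0.87 log units) apart, beyond the scatter of two such steps. The exchange of 2-fluorophenyl for 4-fluorophenyl also changes direction with cyclohexyl present, giving an at least 3.5-fold higher number from compound 2 to compound 4 (0.54 log units; beyond the scatter), whereas it lowered the number with isopropyl present: the same change on two cores in this assay, a 2.1-fold lower number (0.33 log units; beyond the scatter) from compound 1 to compound 3 and an at least 3.5-fold higher number (0.54 log units; beyond the scatter) from compound 2 to compound 4, at least 7.4-fold (0.87 log units) apart, beyond the scatter of two such steps. In this assay compound 4 gives > 128000 nM, a limit and not a number: the limit of > 128000 nM in this assay, at which 1 of the 4 values shown sits.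

The compounds shown leave open how the number moves with other groups on the same nitrogen, such as cyclopropyl or an open-chain butyl group. They also leave open whether the two places remain linked with a 3-fluorophenyl or an unsubstituted phenyl group.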